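The source may report more compounds than this note shows. Statements on the series, on what has been measured and on what is new or still open speak of the compounds shown alone.

Compound 2, `COc1ccc(C2N=C(SCc3ccccc3Cl)NC(C)=C2C(=O)Nc2ccc(F)cc2)cc1OC`, is the starting point here. In a functional assay on the whole organism (artery, strain albino) with Rattus norvegicus as the target, with a stated time of 15 min, at a dose of 10 mg/kg by the oral route (a lower number here means less inhibition, a higher number more inhibition at the dose given (going by the name of the read-out)), compound 2 gives 2.6%. Among the measured compounds shown here, the only other measured compound, compound 1, `COc1ccc(C2N=C(SCc3ccccc3)NC(C)=C2C(=O)Nc2ccc(F)cc2)cc1OC`, gives 1.5% in this assay. The step between them, a number 1.1 percentage points higher from compound 1 to compound 2 (within the scatter), lies within the scatter, so the two numbers cannot be told apart, and compound 2 simply holds the higher of the two near-zero readings without inhibiting more in any reliable sense.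

The change to compound 3, `COc1ccc(C2N=C(SCc3cccc(Cl)c3)NC(C)=C2C(=O)Nc2ccc(F)cc2)cc1OC`, is 3-chlorophenyl in place of 2-chlorophenyl on a saturated chain carbon bound to a sulfur. For the measured compounds named here, no measured step moves a chloro group in this way; the one measured step, adding a chloro group, changed nothing beyond the scatter. Both known numbers sit close to zero, so the expected step of a number 0.1 percentage points lower from compound 2 to compound 3 (within the scatter) is none beyond the scatter. Compound 3 is therefore estimated to give 2.5% in this assay, within a range from -5% to 10%.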

Compound 3, a percentage reported as inhibition, in the whole organism at one dose (the size of the read-out at that dose, not a potency): 2.1%
Compound 3: middle estimate off by 0.4 percentage points, on the high side; the measured number falls inside the stated range.
By their numbers in this assay, from the lowest: compounds 1, 3 and 2 (each within the scatter of the next).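

Swapping 2-chlorophenyl for 3-chlorophenyl on the saturated chain carbon bound to a sulfur gives a number 0.5 percentage points lower from compound 2 to compound 3 (within the scatter) in this assay and so reveals no effect of where the chloro group sits, at least for these two ring placements. Set against the compound with no chloro group, the second placement gives a number 0.6 percentage points higher from compound 1 to compound 3 (within the scatter) so neither chlorinated compound can be told apart from the unsubstituted one, and all three readings remain close to zero. No supporting evidence is available to explain these readings.

As far as these compounds go, what stays open is whether any change at this position can lift the reading clear of the scatter. An amine or a carboxylic acid on the ring, or a longer chain in place of the benzyl group, would test this more sharply than moving a chloro group.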